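The source may report more compounds than this note shows. Statements on the series, on what has been measured and on what is new or still open speak of the compounds shown alone.

In a functional assay on HL-60 cells (Homo sapiens) for antiproliferative activity, with a stated time of 24 h (on this read-out higher numbers stand for weaker inhibition and lower numbers for stronger inhibition), compound 1 `NC(=O)c1c(NC(=O)c2ccccc2Br)sc2c1CCN(C(=S)Nc1ccccc1Cl)C2` gives 14600 nM. Compound 2 `NC(=O)c1c(NC(=O)c2ccccc2Br)sc2c1CCN(C(=S)Nc1ccccc1F)C2` gives > 50000 nM, which is a limit and not a number. Compound 3 `NC(=O)c1c(NC(=O)c2ccccc2Br)sc2c1CCN(C(=S)Nc1ccccc1C(F)(F)F)C2` carries trifluoromethyl in place of the fluoro of compound 2, on an aromatic carbon ortho to a large group: trifluoromethyl in place of fluoro on an aromatic carbon. Within the data shown here, the one measured step at this carbon is an at least 3.4-fold higher number from compound 1 to compound 2 (0.53 log units; beyond the scatter), at least modest and beyond the scatter, and it involves no trifluoromethyl. Leaving fluoro is therefore expected to give a modest step to a lower number in this assay: the expected step is an at least 2.2-fold lower number from compound 2 to compound 3 (0.35 log units; beyond the scatter). For compound 3 the estimate is 22000 nM, with an expected range of 9000 nM to 50000 nM.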

Compound 3, half-maximal inhibitory concentration: 27400 nM
Estimate against measurement, compound 3: 1.2-fold (0.10 log units) below, within the range that was stated.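

In this assay, trifluoromethyl at this aromatic carbon gives a measured number where fluoro gave only a limit, and the reading is an at least 1.8-fold lower number from compound 2 to compound 3 (0.26 log units; that floor lies within the scatter), so the size of this change stays unfixed. Against chloro the reading is a 1.9-fold higher number from compound 1 to compound 3 (0.27 log units; within the scatter), so chloro and trifluoromethyl cannot be told apart at this carbon. The value of compound 2 is a limit and not a number: the limit of > 50000 nM in this assay, at which 1 of the 3 values shown sits.

Open, going by these compounds, is how an amine, a methoxy group or a carboxylic acid on this aromatic carbon would read in this assay. Also open, on these data alone, is how plain hydrogen there would compare with chloro and trifluoromethyl.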